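Methoxy Groups on Two Related Cores Tested for Growth Inhibition

This account rests on a few compounds, and the source may have more. Where it says the series, first, only, none or still open, it means among the compounds named here.

Compound 1 `O=C1C=COC(/C=C/c2ccccc2)C1` is a small molecule carrying a plain phenyl ring. In a functional assay on 786-0 cells (Homo sapiens) for inhibition, read by sulforhodamine B assay, with a stated time of 48 h (on this read-out lower numbers stand for stronger inhibition of growth and higher numbers for weaker inhibition of growth), compound 1 gives 138 uM. Compound 2 `COc1ccc(/C=C/C2CC(=O)C=CO2)cc1` differs from it by one change, (methoxy in place of hydrogen on an aromatic carbon), and in this assay compound 2 gives 192 uM. The step of a 1.4-fold higher number from compound 1 to compound 2 (0.14 log units; within the scatter) is thus small, and the two numbers cannot be told apart with confidence.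

Compound 3 `COc1cc(/C=C/C2CC=CC(=O)O2)cc(OC)c1` rests on a different core; how its core differs from that of compound 1 is not broken down here. In this assay compound 3 gives 10.6 uM, the lowest of the three numbers, with both other compounds well apart from it.

Compound 4 `COc1cc(/C=C/C2CC=CC(=O)O2)cc(OC)c1OC` is reached from compound 3 by methoxy in place of hydrogen on an aromatic carbon. Among the compounds with values here, this is the same kind of change as the one from compound 1 to compound 2, though the place differs: here the new methoxy sits ortho to two methoxy groups, whereas in the earlier pair it did not. Since the step of a 1.4-fold higher number from compound 1 to compound 2 (0.14 log units; within the scatter) lay within the scatter, a similarly small step is expected here, a 1.2-fold higher number from compound 3 to compound 4 (0.09 log units; within the scatter). For compound 4 the estimated value is 13 uM, with a plausible range from 4 uM to 40 uM.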

Compound 4, concentration for growth inhibition (reported as GI): 18.5 uM
The estimate for compound 4 lay 1.4-fold (0.15 log units) below the measured number; the measured number falls inside the stated range.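

In this assay, adding the methoxy group gives a 1.7-fold higher number from compound 3 to compound 4 (0.24 log units; within the scatter), so the two numbers cannot be told apart with confidence. Set beside the earlier pair, the same change gives a similarly small step on both cores: the same change on two cores in this assay, a 1.4-fold higher number (0.14 log units; within the scatter) from compound 1 to compound 2 and a 1.7-fold higher number (0.24 log units; within the scatter) from compound 3 to compound 4, 1.3-fold (0.10 log units) apart, within the scatter of two such steps. This shows that in these two pairs, replacing an aromatic hydrogen with methoxy leaves the growth-inhibition number within the usual scatter, even though the new group in compound 4 sits ortho to two methoxy groups; it does not show that the same would hold on every core or at every place on the ring, since two pairs are too few to support a general rule.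

The compounds shown carry only hydrogen or methoxy on the aromatic ring, leaving open what an amine, a carboxylic acid or a longer chain would do there. Also open is why compound 3 and compound 4 give much lower numbers than compound 1 and compound 2, since those compounds differ in more than one place.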